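The source may hold more compounds than are shown below. What is called first, only, known or untested is meant among the compounds shown, and "the series" means these compounds.

Measured in a functional assay on a cell-free system (Platelet, plasma, Homo sapiens) for inhibition; on this read-out higher numbers stand for weaker inhibition and lower numbers for stronger inhibition:
- Compound 1 `Cc1ccc(N(CCN2CCC(OCC(=O)O)CC2)C(=O)c2ccc(Cl)cc2)cc1`: 690 nM
- Compound 2 `O=C(O)COC1CCN(CCN(C(=O)c2ccc(Cl)cc2)c2ccc(Cl)cc2)CC1`: 1500 nM
- Compound 3 `O=C(O)COC1CCN(CCN(C(=O)c2ccc(-c3ccccc3)cc2)c2ccc(Cl)cc2)CC1`: > 10000 nM, which is a limit of the assay and not a number

Of the two true numbers, the higher belongs to compound 2. The gap between them is a 2.2-fold higher number from compound 1 to compound 2 (0.34 log units; beyond the scatter).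

Compound 4 `O=C(O)COC1CCN(CCN(C(=O)c2cccc(Cl)c2)c2ccc(Cl)cc2)CC1` has not been measured yet. It has the same atoms as compound 2, joined differently: 3-chlorophenyl in place of 4-chlorophenyl on a carbonyl carbon. Here 3-chlorophenyl stands in place of 4-chlorophenyl on a carbonyl carbon.

Two measured steps offer guidance, but neither moves a group in this way. The closer one alters the same group and gives an at least 6.6-fold higher number from compound 2 to compound 3 (0.82 log units; beyond the scatter), but it swaps chloro for phenyl. The other, a 2.2-fold higher number from compound 1 to compound 2 (0.34 log units; beyond the scatter), swaps methyl for chloro elsewhere in the molecule. These steps show that small edits can matter, but they do not indicate a direction, so no step beyond the scatter is the best expectation.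

The estimated value for compound 4 is 1500 nM, with an expected range from 500 nM to 4500 nM. This expectation corresponds to no change at the digits printed from compound 2 to compound 4 (within the scatter).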

Compound 4, half-maximal inhibitory concentration: 350 nM
Estimate against measurement, compound 4: 4.3-fold (0.63 log units) above; measured number outside the range, below it.
By their numbers in this assay, from the lowest: compounds 4 and 1 (each within the scatter of the next); then compound 2. At a limit, above all of these: compound 3.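

In this assay, moving only the chlorine, so that 4-chlorophenyl on the carbonyl carbon becomes 3-chlorophenyl, gives a 4.3-fold lower number from compound 2 to compound 4 (0.63 log units; beyond the scatter). Among the compounds shown here, compounds 2 and 4 hold the same atoms, whereas each earlier step exchanged one group for another, so only this step shows that the place of the chlorine on this ring matters by itself. No measurement shown explains this change.

Going by these compounds, what stays open is whether the gain belongs to chlorine or to any group at that place, such as a methoxy or a nitrile in place of the chlorine of 3-chlorophenyl. It is also unknown whether the same shift of chlorine would lower the number in a compound carrying the methyl group of compound 1.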